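Amide replacement on the oxymethylene-linked core

The source may hold more compounds than are shown below. What is called first, only, known or untested is meant among the compounds shown, and "the series" means these compounds.

Two compounds share the dihydroxyheptanoic acid side chain. Compound 1 `Cc1ccc(CNC(=O)c2nn(-c3ccc(F)cc3)c(CC[C@@H](O)C[C@@H](O)CC(=O)O)c2C(C)C)cc1` gives 2.5 nM in an assay on microsomes from liver for inhibition of 3-hydroxy-3-methylglutaryl-coenzyme A reductase (Rattus norvegicus) (a lower number here means a stronger inhibitor, a higher number a weaker inhibitor), while compound 2 `CC(C)c1c(C(=O)N2CCCCC2)nn(-c2ccc(F)cc2)c1OC[C@@H](O)C[C@@H](O)CC(=O)O` gives 47 nM in this assay, the higher of the two numbers. Compound 3 `COc1cccc(CN(C)C(=O)c2nn(-c3ccc(F)cc3)c(OC[C@@H](O)C[C@@H](O)CC(=O)O)c2C(C)C)c1` carries (3-methoxybenzyl)(methyl)amino in place of piperidin-1-yl on a carbonyl carbon on a carbonyl carbon whose other neighbour is an aromatic carbon. Since compound 1, with its benzyl amide, shows 2.5 nM in this assay, a step downward beyond the scatter from compound 2 to compound 3 is expected, estimated at a 3.1-fold lower number from compound 2 to compound 3 (0.50 log units; beyond the scatter). Compound 3 is therefore expected to reach about 15 nM, within 4 nM to 50 nM.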

Compound 3, half-maximal inhibitory concentration: 21 nM
Estimate against measurement, compound 3: 1.4-fold (0.15 log units) below; the measured number falls inside the stated range.
By their numbers in this assay, from the lowest: compound 1; then compound 3; then compound 2.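

On the carbonyl carbon whose other neighbour is an aromatic carbon, the amine part can be exchanged for a larger one carrying an aromatic ring of carbon only, and the number still falls in this assay (a 2.2-fold lower number from compound 2 to compound 3 (0.35 log units; beyond the scatter)). Among the compounds shown here, this is the first step read at this place on the shared core, and it is modest. Nothing measured here accounts for the step.

The whole amine changes at once, so the shares of the methoxy, the benzyl and the methyl group stay unresolved. From the compounds shown here alone, whether plain benzyl(methyl)amino or morpholin-4-yl would give a similar number remains open.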